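The source may hold more compounds than are shown below. What is called first, only, known or untested is meant among the compounds shown, and "the series" means these compounds.

Among the compounds with values here, compound 1, `C[C@H]1[C@H](NCc2sccc2Br)C[C@H]2C[C@@H]1C2(C)C`, stands at the top of the three numbers so far in an ADME assay on MDCK cells (Canis lupus familiaris) for cytotoxicity, read by microscopy, with a stated time of 48 h (a lower number here means that less compound is tolerated, a higher number that more compound is tolerated), where compound 1 gives 50000 nM. Compound 2, `C[C@H]1[C@H](NCc2sccc2C2CCCCC2)C[C@H]2C[C@@H]1C2(C)C`, gives 1560 nM, and compound 3, `CCCCc1ccsc1CN[C@@H]1C[C@H]2C[C@@H]([C@H]1C)C2(C)C`, gives 25000 nM. The step of a 32-fold lower number from compound 1 to compound 2 (1.51 log units; beyond the scatter) is large, whereas the step of a 2.0-fold lower number from compound 1 to compound 3 (0.30 log units; within the scatter) stays within the scatter, so a bulky cyclohexyl on the aromatic carbon lowered the tolerated concentration far more than a butyl did.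

Compound 4, `Cc1csc(CN[C@@H]2C[C@H]3C[C@@H]([C@H]2C)C3(C)C)n1`, differs from compound 1 by 4-methyl-1,3-thiazol-2-yl in place of 3-bromothiophen-2-yl on a saturated chain carbon bound to an amine nitrogen. Within the data shown here, none of the measured steps exchanges the aromatic ring itself; they all vary the group on an aromatic carbon, and the group entering here, 4-methyl-1,3-thiazol-2-yl, carries only a methyl rather than anything like a cyclohexyl. The closest guide is therefore the small step from compound 1 to compound 3, and no change beyond the scatter is expected in this assay.

For compound 4 the expected value is 50000 nM, between 20000 nM and 100000 nM. This estimate means a step of no change at the digits printed from compound 1 to compound 4 (within the scatter) that is expected to sit within the scatter.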

Compound 4, minimum cytotoxic concentration: > 100000 nM
Compound 4: a limit, no number; the forecaster's own chance of this, stated with the estimate: 25%; middle value at least 2.0-fold (0.30 log units) away from the limit.
By their numbers in this assay, from the lowest: compound 2; then compounds 3 and 1 (each within the scatter of the next). At a limit, above all of these: compound 4.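

The earlier compounds shown here varied only the group on an aromatic carbon, while compound 4 exchanges the aromatic ring itself on the saturated chain carbon bound to an amine nitrogen, and in this assay this exchange gives an at least 2.0-fold higher number from compound 1 to compound 4 (0.30 log units; that floor lies within the scatter). The value of compound 4 is a limit and not a number: the limit of > 100000 nM in this assay, at which 1 of the 4 values shown sits. The exchange of 3-bromothiophen-2-yl for 4-methyl-1,3-thiazol-2-yl therefore brings no fall of the kind seen with cyclohexyl, though the true size of the step cannot be read from the limit.

The compounds shown leave open whether the ring nitrogen, the methyl or the departure of the bromo accounts for this result. They also leave open how a phenyl ring would read here, or a 1,3-thiazol-2-yl ring carrying cyclohexyl, butyl or an amine instead of the methyl.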